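Swapping chloro for cyano on a weakly active compound

The source may report more compounds than this note shows. Statements on the series, on what has been measured and on what is new or still open speak of the compounds shown alone.

Among the compounds with values here, only two numbers are known so far. Compound 1 (`CCn1cc(-c2nc3ccc([N+](=O)[O-])cc3o2)c(=O)c2cc(F)c(N3CCNC(C)C3)c(F)c21`) gives 2650 nM in a functional assay on HepG2 cells (Homo sapiens) for antiproliferative activity, read by MTT assay, with a stated time of 48 h (on this read-out higher numbers stand for weaker inhibition and lower numbers for stronger inhibition), and holds the lower number of the pair. Compound 2 (`CCn1cc(-c2ccc(Cl)cc2)c(=O)c2cc(F)c(N3CCNCC3)cc21`) gives 24000 nM in this assay and holds the higher number, which means the weaker inhibition of the two, and the gap between them lies beyond the usual scatter.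

Compound 3 (`CCn1cc(-c2ccc(C#N)cc2)c(=O)c2cc(F)c(N3CCNCC3)cc21`) keeps all of compound 2 except one group. It has cyano in place of chloro on an aromatic carbon, para to a large group (cyano in place of chloro on an aromatic carbon), so 4-chlorophenyl becomes 4-cyanophenyl.

Within the data shown here, no measured pair shows what this swap does, so nothing here points firmly in either direction. The best anchor is compound 2 at 24000 nM as the closest measured relative, and only a small shift from it is expected, with no change beyond the scatter. The estimated step is a 1.2-fold lower number from compound 2 to compound 3 (0.08 log units; within the scatter) and would be too small to read as a real difference. For compound 3 the expected value is 20000 nM within a range of 7000 nM to 60000 nM in this assay once it is measured.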

Compound 3, half-maximal inhibitory concentration: 12600 nM
For compound 3 the middle estimate is 1.6-fold (0.20 log units) above the measured one, and the stated range covers the measured number.
By their numbers in this assay, from the lowest: compound 1; then compounds 3 and 2 (each within the scatter of the next).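

With compound 2 and compound 3, this position on an aromatic carbon, para to a large group, has its first measured pair, and in this assay replacing chloro with cyano gives a 1.9-fold lower number from compound 2 to compound 3 (0.28 log units; within the scatter) for this single change. Within the data shown here, the two groups therefore cannot be told apart in this read-out, even though the entering cyano counts a hydrogen-bond acceptor and a triple bond, while the leaving chloro has neither, so these differences in the group come with no step that can be read as real. Nothing measured on these compounds speaks to the reason for this result.

As far as these compounds go, what remains open is whether any group at this position can move the number beyond the scatter, and an amine, a carboxylic acid or a longer chain such as propyl would each test that on the same core. Also open, from the compounds shown here alone, is whether the swap of chloro for cyano would give a similar step on a different core, since a single pair cannot show how far this result carries.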